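A few compounds are considered here, and "the series" means these few. Any claim that something is new, unique, unknown or untested is made for them only; others in the source may bear on it.

Measured so far in an ADME assay on HEL cells (Homo sapiens) for cytotoxicity, with a stated time of 3 days; on this read-out lower numbers stand for higher toxicity in this test and higher numbers for lower toxicity in this test:
compound 1 `CCC1(Cc2ccccc2)OS(=O)(=O)C=C1OCc1ccc(Cl)c(Cl)c1`: 36700 nM
compound 2 `CCC1(Cc2ccccc2)OS(=O)(=O)C=C1OCc1ccc([N+](=O)[O-])cc1`: < 200000 nM, a limit of the assay and not a number
compound 3 `CCC1(Cc2ccccc2)OS(=O)(=O)C=C1OCc1ccc(Cl)cc1`: > 200000 nM, a limit of the assay and not a number

For the measured compounds named here, compound 1 carries the only number in this assay; the other two values are limits. Compound 2 sits at the limit of < 200000 nM in this assay, at which 1 of the 3 values shown sits. Compound 3 sits at the limit of > 200000 nM in this assay, at which 1 of the 3 values shown sits.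

Compound 4 `CCC1(Cc2ccccc2)OS(=O)(=O)C=C1OCC=C(C)C` is not yet measured. It differs from compound 1 as 2-methylprop-1-en-1-yl in place of 3,4-dichlorophenyl on a saturated chain carbon bound to an oxygen on an unsaturated carbon: the aromatic ring with both chlorines leaves altogether and a short branched alkenyl chain takes its place.

Of the measured steps, a step that the limit leaves unreadable from compound 1 to compound 2 and a number no lower from compound 2 to compound 3 (the limit leaves the size open) give no readable size. The step of an at least 5.4-fold higher number from compound 1 to compound 3 (0.73 log units; beyond the scatter) shows that removing a single chloro already carries the number past the upper limit of the assay. Because an at least 5.4-fold higher number from compound 1 to compound 3 (0.73 log units; beyond the scatter) follows loss of one chloro, removal of the whole 3,4-dichlorophenyl in compound 4 is expected to raise the number at least as far, toward lower toxicity. Compound 4 is therefore estimated at 150000 nM, with a range from 40000 nM to 400000 nM. This estimate corresponds to an expected step of a 4.1-fold higher number from compound 1 to compound 4 (0.61 log units; beyond the scatter). A limit rather than a number is quite possible for compound 4.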

Compound 4, half-maximal cytotoxic concentration: 112000 nM
Estimate against measurement, compound 4: 1.3-fold (0.13 log units) above; low and high end bracket the measured number.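

In this assay, the aromatic ring at the place on a saturated chain carbon bound to an oxygen on an unsaturated carbon is not needed for a measurable number: 2-methylprop-1-en-1-yl in place of 3,4-dichlorophenyl gives a 3.1-fold higher number from compound 1 to compound 4 (0.48 log units; beyond the scatter). With 4-chlorophenyl as the comparison, the same place gives an at least 1.7-fold lower number from compound 3 to compound 4 (0.25 log units; that floor lies within the scatter), so the series now holds a non-aromatic group whose number lies inside the assay range. Compound 3 holds a limit and not a number: the limit of > 200000 nM in this assay, at which 1 of the 4 values shown sits.

Going by these compounds, the step from compound 2 to compound 4 cannot be read, and compound 2 also holds a limit and not a number: the limit of < 200000 nM in this assay, at which 1 of the 4 values shown sits. Whether a longer saturated chain or an amine at this place gives a number near that of compound 4 stays open.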